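The source may hold more compounds than are shown below. What is called first, only, known or untested is meant among the compounds shown, and "the series" means these compounds.

Compound 1, `Cc1cccc(C)c1-c1cccc(COc2ccc(CC3SC(=O)NC3=O)s2)c1`, carries a 2,4-dioxo-1,3-thiazolidin-5-yl group on the shared core; in a functional assay on cells for agonist activity at Free fatty acid receptor 1 (Homo sapiens), read by calcium flux (a higher number here means a larger maximal response, a lower number a smaller maximal response), compound 1 gives "not determined" (no result reported), so it stands without a number. Two related compounds were measured there: compound 2, `Cc1cccc(C)c1-c1cccc(OCc2cn(CCC(=O)O)nn2)c1`, gives 79.9% in this assay, and compound 3, `Cc1cccc(C)c1-c1cccc(OCc2ccc(CCC(=O)O)s2)c1`, gives 136%. Compound 4, `Cc1cccc(C)c1-c1cccc(COc2ccc(CCC(=O)O)s2)c1`, is reached from compound 1 by one change: carboxymethyl in place of 2,4-dioxo-1,3-thiazolidin-5-yl on a saturated chain carbon bound to an aromatic carbon. With no value for compound 1, the direction of this step cannot be read from the data, and the expectation rests on compounds 2 and 3 alone. On that basis compound 4 is estimated to give 115% in this assay, with a range from 80% to 150%.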

Compound 4, largest response reached (Emax), in percent of the reference or control that the assay uses: 140%
For compound 4 the middle estimate is 25 percentage points below the measured one, and the stated range covers the measured number.
By their numbers in this assay, from the lowest: compound 2; then compounds 3 and 4 (each within the scatter of the next).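

For the compounds shown here, compound 1 has no number to set against compound 4, and no step between them can be read. The compounds shown leave open how 2,4-dioxo-1,3-thiazolidin-5-yl and carboxymethyl compare in this assay. No measured evidence bears on this result.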